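The source may report more compounds than this note shows. Statements on the series, on what has been measured and on what is new or still open speak of the compounds shown alone.

In a physicochemical assay for solubility, at pH 6.8 (on this read-out lower numbers stand for lower solubility and higher numbers for higher solubility), compound 1 (`Nc1cc(C(F)(F)F)c(Br)nc1C(=O)NCCC(F)(F)F`) gives 49 ug/mL, compound 2 (`CC(O)CNC(=O)c1nc(Br)c(C(F)(F)F)cc1N`) gives 120 ug/mL, and compound 3 (`Nc1cc(C(F)(F)F)c(Br)nc1C(=O)NC[C@H](O)C(F)(F)F`) gives 290 ug/mL, the highest of the three numbers. Compound 4 (`Nc1cc(C(F)(F)F)c(Br)nc1C(=O)NC[C@@H](O)C(F)(F)F`) differs from compound 3 only in its spatial arrangement: the two compounds have the same atoms and bonds and differ only in configuration as drawn: 1 of 1 stereo elements differ; a stereocentre at a saturated chain carbon is drawn S in compound 3 and R in compound 4. A stereocentre at a saturated chain carbon is drawn S in compound 3 and R in compound 4. The measured steps are all modest: a 2.4-fold higher number from compound 1 to compound 2 (0.39 log units; beyond the scatter), a 5.9-fold higher number from compound 1 to compound 3 (0.77 log units; beyond the scatter) and a 2.4-fold higher number from compound 2 to compound 3 (0.38 log units; beyond the scatter). Each of them changes atoms, so none directly measures a change of configuration. No step beyond the scatter is therefore expected in this assay, and the estimated change is no change at the digits printed from compound 3 to compound 4 (within the scatter). For compound 4, the expected value is 290 ug/mL, with an estimated range of 150 ug/mL to 520 ug/mL.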

Compound 4, solubility: 177 ug/mL
Beside the measured number, compound 4's estimate is 1.6-fold (0.21 log units) above it; the measured number falls inside the stated range.
By their numbers in this assay, from the lowest: compound 1; then compounds 2, 4 and 3 (each within the scatter of the next, the first and the last beyond it).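

In this assay, among the compounds shown here, a change of configuration alone is read directly for the first time: a 1.6-fold lower number from compound 3 to compound 4 (0.21 log units; within the scatter), so the drawn S and R forms stand within the scatter of each other. With the R centre, the 2,2,2-trifluoro-1-hydroxyethyl group in place of 1-hydroxyethyl gives a 1.5-fold higher number from compound 2 to compound 4 (0.17 log units; within the scatter), which is also within the scatter. Hydroxy in place of hydrogen still gives a step beyond the scatter with either configuration, here a 3.6-fold higher number from compound 1 to compound 4 (0.56 log units; beyond the scatter). The compounds shown leave open whether an amine or a methoxy group in place of that hydroxy would give similar numbers, and whether configuration would then matter.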